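Switching the quinolinyl arm of compound 2 for a thiophenyl

The source may report more compounds than this note shows. Statements on the series, on what has been measured and on what is new or still open speak of the compounds shown alone.

Measured compounds:
compound 1 `CCOC(=O)c1cnc(C(C)(C)C)nc1NN1C(=O)C=C(C)C1=O`, 1000 nM
compound 2 `CCOC(=O)c1cnc(-c2cnc3ccccc3c2)nc1NN1C(=O)C=C(C)C1=O`, 6000 nM

The read-out is a functional assay on Jurkat cells for inhibition of nuclear factor NF-kappa-B complex (Homo sapiens); a higher number here means a weaker inhibitor, a lower number a stronger inhibitor. Compound 1 gives 1000 nM. Going by the values given here, compound 2, carrying quinolin-3-yl in place of tert-butyl on an aromatic carbon, gives 6000 nM, the higher of the two numbers, and the one step measured so far is a 6.0-fold higher number from compound 1 to compound 2 (0.78 log units; beyond the scatter).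

Compound 3 `CCOC(=O)c1cnc(-c2ccsc2)nc1NN1C(=O)C=C(C)C1=O` is the next compound. Its change from compound 2 is thiophen-3-yl in place of quinolin-3-yl on an aromatic carbon. Among the compounds with values here, no measured step involves thiophen-3-yl, so the only guide is that the step from the tert-butyl to the quinolin-3-yl group was a 6.0-fold higher number from compound 1 to compound 2 (0.78 log units; beyond the scatter), and that thiophen-3-yl is a much smaller aromatic group than quinolin-3-yl. Compound 3 is therefore expected to land between compound 1 and compound 2, with a 2.0-fold lower number from compound 2 to compound 3 (0.30 log units; within the scatter) as the estimated step. For compound 3 in this assay the estimate is 3000 nM, within a range of 1000 nM to 10000 nM.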

Compound 3, half-maximal inhibitory concentration: 100 nM
Compound 3: middle estimate off by 30-fold (1.48 log units), on the high side; the measured number lies below the stated range.
By their numbers in this assay, from the lowest: compound 3; then compound 1; then compound 2.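

Going by these compounds alone, the change from quinolin-3-yl to thiophen-3-yl, on the aromatic carbon between two ring nitrogen atoms, gives a 60-fold lower number from compound 2 to compound 3 (1.78 log units; beyond the scatter) in this assay, so this position responds far more strongly to the choice of aromatic group than the single earlier step could show. Compound 1 and compound 2 alone left open the reading that an aromatic group here is worse than tert-butyl, but thiophen-3-yl gives a 10-fold lower number from compound 1 to compound 3 (1.00 log units; beyond the scatter), so the aromatic groups at this position fall on both sides of tert-butyl, with compound 2 above it and compound 3 below it. Nothing available explains why the two aromatic groups part so widely.

The step from compound 2 to compound 3 changes several things at once, replacing two fused six-membered aromatic rings with one five-membered aromatic ring and ring nitrogen with sulfur, so the compounds shown cannot say which of these changes matters. As far as these compounds go, whether the low number belongs to sulfur, to the single ring or to the ring size remains open, and a phenyl, a pyridin-3-yl or a furan-3-yl group at this position would begin to separate these.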